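Three Limits and a Dimethoxyphenyl Newcomer

The compounds below may be only part of what the source reports. "The series", "measured", "known", "first", "only" and "open" are said of these compounds alone.

This set asks whether biaryl amides carrying a long acid-tipped chain harm liver-derived cells in an ADME assay on HepG2 cells (Homo sapiens) for cytotoxicity, read by CellTiter-Glo and resazurin assay, with a stated time of 72 h; on this read-out lower numbers stand for an effect already at smaller amounts and higher numbers for an effect only at larger amounts of compound. Compound 1 `CC(C)N(Cc1cccc(OCCCCCC(=O)O)c1)C(=O)c1ccc(-c2cccc(N(C)C)c2)cc1` gives only a limit, > 26000 nM. Compound 2 `CC(C)N(Cc1cccc(OCCCCCC(=O)O)c1)C(=O)c1ccc(-c2ccncc2)cc1` likewise gives only a limit, > 26000 nM. Compound 3 `CC(=O)c1cccc(-c2ccc(C(=O)N(Cc3cccc(OCCCCCC(=O)O)c3)C(C)C)cc2)c1` also gives only a limit, > 26000 nM. Going by the values given here, because all three sit at the same boundary (the limit of > 26000 nM in this assay, at which 3 of the 3 values shown sit), none of the measured steps can be sized: a step that the two limits leave unreadable from compound 1 to compound 2, a step that the two limits leave unreadable from compound 1 to compound 3 and a step that the two limits leave unreadable from compound 2 to compound 3 are all unreadable. Compound 4 `COc1cc(OC)cc(-c2ccc(C(=O)N(Cc3cccc(OCCCCCC(=O)O)c3)C(C)C)cc2)c1` differs from compound 2 in one place: 3,5-dimethoxyphenyl in place of pyridin-4-yl on an aromatic carbon. Among the compounds with values here, the steps that bear on it are those among compounds 1, 2 and 3, and they only show that swapping the outer aryl ring between a dimethylamino-bearing phenyl, a pyridinyl and an acetyl-bearing phenyl never produced a readable effect in this assay. No step beyond the scatter is therefore expected for compound 4 in this assay, and a fourth limit is the likeliest outcome; the step is estimated as a step that the limit leaves unreadable from compound 2 to compound 4. Compound 4 is expected to give about 30000 nM, within 20000 nM to 60000 nM.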

Compound 4, half-maximal effective concentration: > 26000 nM
Compound 4: no number, only a limit; the forecaster's own chance of this, stated with the estimate: 85%; the middle value does not contradict the limit.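

No step from compound 1, compound 2 or compound 3 to compound 4 can be read, because all four compounds end at the same boundary: the limit of > 26000 nM in this assay, at which 4 of the 4 values shown sit.

How far apart these four compounds truly lie in this assay, and whether any outer ring shown changes their effect on the cells, stays open.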